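Cyclopropyl on the core of compound 1

The source may hold more compounds than are shown below. What is called first, only, known or untested is meant among the compounds shown, and "the series" means these compounds.

Among the measured compounds shown here, compound 1 `FC(F)(F)c1ccccc1-c1ccc2[nH]ncc2c1` gives 164 nM in an assay on CHO-TREX cells for antagonist activity at transient receptor potential cation channel subfamily A member 1 (Homo sapiens), read by FLIPR and calcium flux, with a stated time of 10 min (on this read-out higher numbers stand for weaker inhibition and lower numbers for stronger inhibition), the lowest of the three numbers so far. Compound 2 `FC(F)c1ccccc1-c1ccc2[nH]ncc2c1` gives 2200 nM and compound 3 `Cn1ncc2cc(-c3ccccc3C(F)(F)F)ccc21` gives 7410 nM; the steps are a 13-fold higher number from compound 1 to compound 2 (1.13 log units; beyond the scatter) and a 45-fold higher number from compound 1 to compound 3 (1.65 log units; beyond the scatter), both large and both at places other than the one now changed.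

Compound 4 `FC(F)(F)c1ccccc1-c1cc2cn[nH]c2cc1C1CC1` differs from compound 1 in one place: cyclopropyl in place of hydrogen on an aromatic carbon. Neither measured step bears directly on this change; the step to compound 2 alters the trifluoromethyl group and the step to compound 3 alters the aromatic nitrogen, while the carbon now substituted is left untouched in both. For the measured compounds named here, there is therefore no precedent for adding a group at this position, and the expectation rests on the size of the change alone.

The number for compound 4 is expected to move by a 1.6-fold higher number from compound 1 to compound 4 (0.20 log units; within the scatter), so compound 4 is estimated at 260 nM, with a range from 60 nM to 1200 nM in this assay.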

Compound 4, half-maximal inhibitory concentration: 61 nM
For compound 4 the middle estimate is 4.3-fold (0.63 log units) above the measured one; the measured number falls inside the stated range.
By their numbers in this assay, from the lowest: compound 4; then compound 1; then compound 2; then compound 3.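

In this assay, cyclopropyl in place of hydrogen on this aromatic carbon gives a 2.7-fold lower number from compound 1 to compound 4 (0.43 log units; beyond the scatter) and is the only step shown that lowers the number; the changes at the trifluoromethyl group and the aromatic nitrogen both raise it. This carbon, ortho to a large group and para to a fused ring, therefore accepts a cyclopropyl ring with no loss of inhibition on this read-out, and it is the one place shown where a change improves on compound 1. Nothing measured here accounts for the lower number.

From the compounds shown here alone, it remains open whether the gain is particular to cyclopropyl or would also appear with a methyl, a longer chain, an amine or a carboxylic acid on the same carbon. Also open, going by these compounds, is whether cyclopropyl here would lower the number in the same way on compound 2 and compound 3.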